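Adding a Chloro Group to Compound 2

The source may hold more compounds than are shown below. What is called first, only, known or untested is meant among the compounds shown, and "the series" means these compounds.

Three compounds have been measured in a functional assay on HCC 2998 cells (Homo sapiens) for cytotoxicity, read by sulforhodamine B assay, with a stated time of 48 h; a lower number here means that less compound is tolerated, a higher number that more compound is tolerated:

Compound 1, `ClCc1ccccc1Cn1cnc2c(Cl)nc(Cl)nc21`, gives 6160 nM.
Compound 2, `ClCc1ccccc1Cn1cnc2ncnc(Cl)c21`, gives 7940 nM.
Compound 3, `ClCc1cccc(Cn2cnc3nc(Cl)nc(Cl)c32)c1`, gives 5750 nM.

Compound 2 gives the highest of the three numbers, yet compound 1 and compound 3 each lie within the usual scatter of it, so the three measurements cannot be told apart. For the measured compounds named here, no pair among them differs in only one place, so no single step has been measured.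

Compound 4, `ClCc1ccccc1Cn1cnc2nc(Cl)nc(Cl)c21`, has not yet been measured. It differs from compound 2 by chloro in place of hydrogen on an aromatic carbon, the new chloro group sitting between two ring nitrogen atoms. Compound 1 and compound 3 both carry two chloro groups on the shared core and sit within the scatter of compound 2, so no step beyond the scatter is expected in this assay. The step from compound 2 to compound 4 is therefore estimated as a 1.2-fold lower number from compound 2 to compound 4 (0.09 log units; within the scatter). For compound 4 the expected value is 6500 nM, with a range from 3000 nM to 14000 nM.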

Compound 4, concentration lethal to 50% of the cells: 66100 nM
Compound 4: the middle estimate sits 10-fold (1.01 log units) below what was measured, outside the stated range (above it).
By their numbers in this assay, from the lowest: compounds 3, 1 and 2 (each within the scatter of the next); then compound 4.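

In this assay, putting a chloro group in place of hydrogen on the aromatic carbon between two ring nitrogen atoms gives an 8.3-fold higher number from compound 2 to compound 4 (0.92 log units; beyond the scatter) and this is the first single change shown whose size lies beyond the scatter. The earlier compounds shown here could not show this, since they stood within the scatter of one another and no pair differed in only one place; here one added chlorine atom at this position means that much more compound is tolerated by the cells. Nothing available explains why this step is so large.

As far as these compounds go, it remains open whether the step belongs to chloro itself or would follow from any group placed here. An amine or a methoxy group at this same position would help to separate those two readings.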